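A methyl step at the assay limit

The source may report more compounds than this note shows. Statements on the series, on what has been measured and on what is new or still open speak of the compounds shown alone.

In a functional assay on KB cells (Homo sapiens) for cytotoxicity (on this read-out lower numbers stand for stronger inhibition and higher numbers for weaker inhibition), compound 1 (`CCOCn1cc(C#N)c2c(N)ncnc21`) gives > 100000 nM as a limit of the assay and not a number. Compound 2 (`N#Cc1cn(Cc2ccccc2)c2ncnc(N)c12`) gives > 100000 nM as a limit as well, so its standing is known only as a limit. For the measured compounds named here, the one measured step is a step that the two limits leave unreadable from compound 1 to compound 2 and offers no size to carry forward. Compound 3 (`Cc1ccc(Cn2cc(C#N)c3c(N)ncnc32)cc1`) brings methyl in place of hydrogen on an aromatic carbon in the form of methyl in place of hydrogen on an aromatic carbon, para to a large group. Going by the values given here, no measured step covers this change. With compound 2 at > 100000 nM as the starting limit, no step beyond the scatter is expected in this assay in either direction. The expected step is a number no higher from compound 2 to compound 3 (the limit leaves the size open) and rests on little. For compound 3 the estimated value is 100000 nM with 40000 nM to 250000 nM as the expected range.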

Compound 3, half-maximal inhibitory concentration: > 100000 nM
Compound 3: no number, only a limit (the forecaster's own chance of this, stated with the estimate: 85%); the middle value lies on the limit itself.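

No step can be read from compound 2 to compound 3 in this assay, since both results are limits of the assay and not numbers: the limit of > 100000 nM in this assay, at which 3 of the 3 values shown sit.

The compounds shown leave open how methyl in place of hydrogen on an aromatic carbon changes the read-out, as compound 1, compound 2 and compound 3 give no number to compare.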